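Swapping a butoxy chain for pyridin-3-yl on compound 1

The compounds below may be only part of what the source reports. "The series", "measured", "known", "first", "only" and "open" are said of these compounds alone.

Compound 1 `CCCCOc1ccc(OCCCNC(C)C)cc1` was tested in an assay for inhibition of squalene synthase (Rattus norvegicus), using microsomes (on this read-out lower numbers stand for stronger inhibition and higher numbers for weaker inhibition), where compound 1 gives 56 nM. Among the two numbers measured, this is the highest; the only other measured compound, compound 2 `C=CCc1cc(OCCCC)ccc1OCCCNC(C)C`, gives 0.6 nM in this assay. Among the compounds with values here, the single measured step, allyl in place of hydrogen on an aromatic carbon, brings a 93-fold lower number from compound 1 to compound 2 (1.97 log units; beyond the scatter). Compound 3 `CC(C)NCCCOc1ccc(-c2cccnc2)cc1` has not been measured yet; it differs from compound 1 by pyridin-3-yl in place of butoxy on an aromatic carbon. Within the data shown here, no measured step touches that position or that kind of exchange: the step from compound 1 to compound 2 changes another aromatic carbon and leaves the butoxy group in place, so it says nothing direct about removing the butoxy group and putting an aromatic ring there. In the absence of any step that bears on this change, the estimate for compound 3 is placed close to compound 1 with a wide range, expecting a 1.4-fold higher number from compound 1 to compound 3 (0.15 log units; within the scatter) in this assay. Compound 3 is therefore estimated at 80 nM, within a range from 15 nM to 450 nM.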

Compound 3, half-maximal inhibitory concentration: > 2500 nM
Compound 3 gave a limit, no number (the forecaster's own chance of this, stated with the estimate: 5%); at least 31-fold (1.49 log units) between middle value and limit.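

In this assay, the aromatic carbon that carries the butoxy group, para to a group of 8 heavy atoms, proves sensitive to what stands on it: pyridin-3-yl in place of butoxy brings an at least 44-fold higher number from compound 1 to compound 3 (1.64 log units; beyond the scatter). Within the data shown here, until this result, the only measured step had changed another aromatic carbon and left the butoxy group in place, so this is the first evidence that the exchange of this chain for an aromatic ring can cost a large part of the inhibition seen with compound 1. Compound 3 gives no number, only a limit of the assay, so its step is bounded from one side and its full size stays unknown: the limit of > 2500 nM in this assay, at which 1 of the 3 values shown sits.

The single exchange removes a chain and introduces a ring with a hetero atom at once, so the compounds shown cannot separate what is lost with the butoxy group from what the pyridin-3-yl group brings. A methoxy group or a longer hexyloxy chain at this carbon would test the chain, while a phenyl ring would test the ring nitrogen, and an allyl group added to compound 3 would show whether that earlier step carries over.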